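Swapping a benzyl ring for a fluorophenoxyethyl chain

The compounds below may be only part of what the source reports. "The series", "measured", "known", "first", "only" and "open" are said of these compounds alone.

Compound 1 `C[C@H](NC(=O)c1c(C(F)(F)F)nnn1Cc1ccc(F)cc1)c1ccc(C(=O)O)cc1`: in a functional assay on CHO cells for antagonist activity at prostaglandin E2 receptor EP4 subtype (Homo sapiens), read by calcium flux, with a stated time of 15 min (on this read-out lower numbers stand for stronger inhibition and higher numbers for weaker inhibition), compound 1 gives 2320 nM
Compound 2 `C[C@H](NC(=O)c1c(C(F)(F)F)nnn1Cc1ccc(C(F)(F)F)cc1)c1ccc(C(=O)O)cc1`: compound 2 gives 225 nM
Compound 3 `C[C@H](NC(=O)c1c(C(F)(F)F)nnn1Cc1cccc(C(F)(F)F)c1)c1ccc(C(=O)O)cc1`: compound 3 gives 1970 nM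

Compound 3 has the second highest number of the three. Its number and that of compound 1 lie within the scatter, while an 8.8-fold higher number from compound 2 to compound 3 (0.94 log units; beyond the scatter). Compound 4 `C[C@H](NC(=O)c1c(C(F)(F)F)nnn1CCOc1ccc(F)cc1)c1ccc(C(=O)O)cc1` differs from compound 3 in one place: (4-fluorophenoxy)methyl in place of 3-(trifluoromethyl)phenyl on a saturated chain carbon bound to an aromatic nitrogen. Going by the values given here, two measured steps bear on this: a 1.2-fold lower number from compound 1 to compound 3 (0.07 log units; within the scatter) and an 8.8-fold higher number from compound 2 to compound 3 (0.94 log units; beyond the scatter). Among the compounds with values here, compound 4 brings back a 4-fluorophenyl ring, as in compound 1, but now joined through a 2-(4-fluorophenoxy)ethyl chain that no measured compound carries. The number for compound 4 is therefore expected near that of compound 1, with a 1.5-fold higher number from compound 3 to compound 4 (0.18 log units; within the scatter) as the estimated step. Compound 4 is expected to give 3000 nM, in a range from 800 nM to 12000 nM.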

Compound 4, half-maximal inhibitory concentration: 276 nM
Beside the measured number, compound 4's estimate is 11-fold (1.04 log units) above it; measured number outside the range, below it.
By their numbers in this assay, from the lowest: compounds 2 and 4 (each within the scatter of the next); then compounds 3 and 1 (each within the scatter of the next).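

At this position a 4-fluorophenyl ring can work well when it is carried on a 2-(4-fluorophenoxy)ethyl chain: there is an 8.4-fold lower number from compound 1 to compound 4 (0.92 log units; beyond the scatter) and a 7.1-fold lower number from compound 3 to compound 4 (0.85 log units; beyond the scatter) in this assay, while a 1.2-fold higher number from compound 2 to compound 4 (0.09 log units; within the scatter) places this chain level with the 4-(trifluoromethyl)phenyl group of compound 2. So the position tolerates a change in the link as well as in the ring. Nothing available explains this gain.

On these data alone, whether the ether oxygen or the longer link matters remains open. A 3-(4-fluorophenyl)propyl chain, with carbon in place of that oxygen, or an amine there, would help separate the two.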